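A Carbamoyl Arm Added to a Weakly Active Core

The compounds below may be only part of what the source reports. "The series", "measured", "known", "first", "only" and "open" are said of these compounds alone.

Compound 1 `CCSc1nnc(-c2cc(OC)c(OC)c(OC)c2)n1-c1ccc(OC)cc1` is the reference point. Among the measured compounds shown here, in a functional assay on PC-3 cells (Homo sapiens) for inhibition, read by MTT assay, with a stated time of 48 h (on this read-out higher numbers stand for weaker inhibition and lower numbers for stronger inhibition), compound 1 gives 57700 nM, the only actual number among the three measured compounds. Compound 2 `COc1ccc(C(=O)CSc2nnc(-c3cc(OC)c(OC)c(OC)c3)n2-c2ccc(OC)cc2)cc1` reaches only the limit > 60000 nM in this assay. Compound 3 `COc1ccc(-n2c(SCC(=O)c3ccc4ccccc4c3)nnc2-c2cc(OC)c(OC)c(OC)c2)cc1` likewise reaches only the limit > 60000 nM. The step of an at least 1.0-fold higher number from compound 1 to compound 2 (0.01 log units; that floor lies within the scatter) and the step of an at least 1.0-fold higher number from compound 1 to compound 3 (0.01 log units; that floor lies within the scatter) both sit at the floor set by the limit of > 60000 nM in this assay, at which 2 of the 3 values shown sit. Compound 4 `COc1ccc(NC(=O)CSc2nnc(-c3cc(OC)c(OC)c(OC)c3)n2-c2ccc(OC)cc2)cc1` differs from compound 1 by (4-methoxyphenyl)carbamoyl in place of methyl on a saturated chain carbon bound to a sulfur. Because the comparable step an at least 1.0-fold higher number from compound 1 to compound 2 (0.01 log units; that floor lies within the scatter) stays at the limit, no shift beyond the scatter is expected, and a limit is again likely. For compound 4 the expected value is 70000 nM, within 40000 nM to 150000 nM. The expected step is a 1.2-fold higher number from compound 1 to compound 4 (0.08 log units; within the scatter).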

Compound 4, half-maximal inhibitory concentration: 25800 nM
Compound 4: the middle estimate sits 2.7-fold (0.43 log units) above what was measured, and the stated range ends above it.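

On the saturated chain carbon bound to a sulfur, (4-methoxyphenyl)carbamoyl is the only group shown that moves the read-out beyond the scatter, with a 2.2-fold lower number from compound 1 to compound 4 (0.35 log units; beyond the scatter). What sits on the carbonyl carbon matters: the amino link in place of a direct 4-methoxyphenyl gives an at least 2.3-fold lower number from compound 2 to compound 4 (0.36 log units; beyond the scatter), and replacing naphthalen-2-yl gives an at least 2.3-fold lower number from compound 3 to compound 4 (0.36 log units; beyond the scatter). These last two steps are only floors, set by a limit: the limit of > 60000 nM in this assay, at which 2 of the 4 values shown sit.

From the compounds shown here alone, whether a carboxylic acid or a dimethylamino group on that carbonyl carbon would act the same stays open. So does the effect of a longer chain between the sulfur and the carbonyl.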